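This account rests on a few compounds, and the source may have more. Where it says the series, first, only, none or still open, it means among the compounds named here.

Three compounds have been measured in an ADME assay on cells (Homo sapiens) for cytotoxicity, read by polymerase chain reaction, with a stated time of 3 days; on this read-out higher numbers stand for lower toxicity in this test and lower numbers for higher toxicity in this test:

compound 1, `Nc1nc(Cl)c(-c2nc3ccccc3s2)c(N[C@@H]2C[C@H](CO)[C@@H](O)[C@H]2O)n1`, gives 14000 nM
compound 2, `Nc1nc(Cl)c(-c2nc3ccc(F)cc3s2)c(N[C@@H]2C[C@H](CO)[C@@H](O)[C@H]2O)n1`, gives only the limit > 25000 nM, which is a bound of the assay and not a number
compound 3, `COCCNc1nc(C)c(-c2nc3ccccc3s2)c(N[C@@H]2C[C@H](CO)[C@@H](O)[C@H]2O)n1`, gives 21000 nM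

Compound 3 thus holds the highest of the two plain numbers, but its gap to compound 1 falls within the usual scatter, so the two cannot be told apart on this read-out. Among the compounds with values here, the one step between measured neighbours, an at least 1.7-fold higher number from compound 1 to compound 2 (0.25 log units; that floor lies within the scatter), is itself capped by the limit of > 25000 nM in this assay, at which 1 of the 3 values shown sits, so its true size is unknown.

The unmeasured compound 4, `Cc1nc(NCc2cccnc2)nc(N[C@@H]2C[C@H](CO)[C@@H](O)[C@H]2O)c1-c1nc2ccccc2s1`, differs from compound 3 by pyridin-3-yl in place of methoxymethyl on a saturated chain carbon bound to a nitrogen on an aromatic ring. No measured pair changes this part of the molecule, so the step from compound 1 to compound 2 does not bear on it, and no shown step gives a direction for it. The account therefore expects no change beyond the scatter in this assay for compound 4 relative to compound 3, that is, a step of no change at the digits printed from compound 3 to compound 4 (within the scatter). Compound 4 is estimated at 21000 nM, with a range from 8000 nM to 50000 nM, bearing in mind that a reading this high may come back only as a limit.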

Compound 4, half-maximal cytotoxic concentration: 5000 nM
For compound 4 the middle estimate is 4.2-fold (0.62 log units) above the measured one; the whole stated range lies above it.
By their numbers in this assay, from the lowest: compound 4; then compounds 1 and 3 (each within the scatter of the next). At a limit, above all of these: compound 2.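

Changing this place clearly moves the read-out: in this assay the exchange of 2-methoxyethyl for (pyridin-3-yl)methyl gives a 4.2-fold lower number from compound 3 to compound 4 (0.62 log units; beyond the scatter) and is the first shown step with a size that can be read beyond the scatter. Compounds 1, 2 and 3 gave no sign of higher toxicity in this test, whereas this lower number shows that the group on the chain carbon bound to a nitrogen on an aromatic ring can shift the result in that direction. This one step cannot separate the part played by the ring from that of its nitrogen or of the larger count of heavy atoms, and nothing shown here gives a reason for the change.

Going by these compounds, it remains open whether a phenyl ring or a pyridin-4-yl ring at the same place would read like compound 4, and whether a longer ether chain or a terminal amine would stay close to compound 3. It is also open whether fluoro in place of hydrogen on an aromatic carbon, shown only from compound 1 to compound 2, would raise the number of compound 4.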